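Bromo to methoxy change across two related cores

This account rests on a few compounds, and the source may have more. Where it says the series, first, only, none or still open, it means among the compounds named here.

Compound 1, `O=C(/C=C/c1csc2ccccc12)c1cc(Br)ccc1O`, gives 1040 nM in a functional assay on MCF7 cells (Homo sapiens) for antiproliferative activity, read by sulforhodamine B assay, with a stated time of 72 h; a higher number here means a weaker inhibitor, a lower number a stronger inhibitor.
Compound 2, `COc1ccc(O)c(C(=O)/C=C/c2csc3ccccc23)c1`, gives 750 nM in this assay.
Compound 3, `O=C(/C=C/c1cc2ccccc2s1)c1cc(Br)ccc1O`, gives only a limit in this assay, namely > 10000 nM.

Among the compounds with values here, the one measured step is methoxy in place of bromo on an aromatic carbon, which gave a 1.4-fold lower number from compound 1 to compound 2 (0.14 log units; within the scatter). Compound 3 shares its atoms with compound 1 but joins them differently; the difference between the two cores is not broken down here. Compound 4, `COc1ccc(O)c(C(=O)/C=C/c2cc3ccccc3s2)c1`, carries the same change on the core of compound 3: methoxy in place of bromo on an aromatic carbon, at a place described in the same words as for compound 2.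

Since the change left compound 1 and compound 2 within the scatter in this assay, compound 4 is expected to stay close to compound 3, and compound 3 sits at the limit of > 10000 nM in this assay, at which 1 of the 3 values shown sits. The step from compound 3 to compound 4 is therefore estimated as a step that the limit leaves unreadable from compound 3 to compound 4. For compound 4 in this assay the expected value is 15000 nM, in the range 5000 nM to 50000 nM, most likely reported again only as a limit.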

Compound 4, half-maximal inhibitory concentration: > 10000 nM
Compound 4 ended at the assay's limit (the forecaster's own chance of this, stated with the estimate: 75%); the middle value lies beyond the limit too.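

In this assay compound 3 gives > 10000 nM as a limit. Within the data shown here, compound 4 gives > 10000 nM in this assay as a limit too, so no step between the two can be read. The compounds shown leave open whether methoxy in place of bromo changes activity on the core of compound 3, and how far either compound lies past the limit.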